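This account rests on a few compounds, and the source may have more. Where it says the series, first, only, none or still open, it means among the compounds named here.

Compound 1, `C#CCn1cc(C(=O)NCCCOC(=O)[C@H]2CCCN2C(=O)OC(C)(C)C)c(=O)c2ccc(Cl)nc21`: in a functional assay on PaCa cells (Homo sapiens) for cytotoxicity, read by MTT assay, with a stated time of 72 h (on this read-out lower numbers stand for stronger inhibition and higher numbers for weaker inhibition), compound 1 gives 7600 nM.
Compound 2, `C#CCn1cc(C(=O)NCCCOC(=O)[C@H](C)NC(=O)OC(C)(C)C)c(=O)c2ccc(Cl)nc21`: in this assay compound 2 gives > 10000 nM, a limit of the assay rather than a number.

Among the compounds with values here, compound 1 therefore holds the only real number among the two values shown; the other is a limit, and the limit of > 10000 nM in this assay, at which 1 of the 2 values shown sits, marks where compound 2 sits. Within the data shown here, the single measured step, an at least 1.3-fold higher number from compound 1 to compound 2 (0.11 log units; that floor lies within the scatter), exchanges the acid part of the ester at the end of the chain and touches nothing on the aromatic rings, so it bears only indirectly on the change examined here. Compound 3, `C#CCn1cc(C(=O)NCCCOC(=O)[C@H]2CCCN2C(=O)OC(C)(C)C)c(=O)c2ccc(C)nc21`, differs from compound 1 by methyl in place of chloro on an aromatic carbon, on an aromatic carbon of a six-membered aromatic ring with one nitrogen, next to the ring nitrogen, meta to a fused ring and para to a fused ring. Among the measured compounds shown here, no measured step alters this ring, so there is nothing to fix a direction for this assay. The step from compound 1 to compound 3 is expected to be no change at the digits printed from compound 1 to compound 3 (within the scatter), that is, no shift beyond the usual scatter. Compound 3 is accordingly estimated at 7600 nM, with a range from 2500 nM to 20000 nM.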

Compound 3, half-maximal inhibitory concentration: > 10000 nM
Compound 3 ended at the assay's limit (the forecaster's own chance of this, stated with the estimate: 35%); middle value at least 1.3-fold (0.11 log units) away from the limit.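

Within the data shown here, this is the first measured change on the aromatic ring of the shared core: chloro gives way to methyl on an aromatic carbon next to the ring nitrogen, and the rest of compound 1 stays the same. In this assay compound 3 gives > 10000 nM, which is a limit of the assay and not a number. The step is an at least 1.3-fold higher number from compound 1 to compound 3 (0.11 log units; that floor lies within the scatter), so methyl shows no sign of improving on chloro at this place, although the printed floor alone does not separate the two compounds, and compound 3 joins compound 2 at the same limit: the limit of > 10000 nM in this assay, at which 2 of the 3 values shown sit.

The compounds shown leave open how far compound 3 really lies from compound 1, and so whether the exchange of chloro for methyl matters at all in this assay. Also open, as far as these compounds go, is how an amine or a bromine atom on this same aromatic carbon would read, and whether either would give a real number rather than a limit.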